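A few compounds are considered here, and "the series" means these few. Any claim that something is new, unique, unknown or untested is made for them only; others in the source may bear on it.

For the measured compounds named here, compound 2 `O=C(/C=C/c1ccc(OCc2nc(C3CCN(Cc4ccccc4F)CC3)no2)cc1)NO` is one of two compounds measured in an assay on isolated protein for inhibition of protein deacetylase HDAC6 (Homo sapiens), read by fluorescence, with a stated time of 1 h, tested at 100 nM (on this read-out lower numbers stand for less inhibition and higher numbers for more inhibition at the one concentration tested (going by the name of the read-out)), where compound 2 gives 68%. Going by the values given here, its only comparison is compound 1 `Cc1ccc(CN2CCC(c3noc(COc4ccc(/C=C/C(=O)NO)cc4)n3)CC2)cc1`, which in this assay gives 76%; compound 2 sits at the bottom of these two numbers, but the step of a number 8 percentage points lower from compound 1 to compound 2 (within the scatter) is within the scatter, so the two read as the same. Compound 3 `O=C(/C=C/c1ccc(OCc2nc(C3CCN(Cc4ccc(Br)cc4)CC3)no2)cc1)NO` is the next compound, and it differs from compound 2 by 4-bromophenyl in place of 2-fluorophenyl on a saturated chain carbon bound to an amine nitrogen in a ring. Among the compounds with values here, the one measured step that bears on this, a number 8 percentage points lower from compound 1 to compound 2 (within the scatter), exchanged one substituted phenyl for another at the same place and produced no change beyond the scatter. On that basis a similar outcome is expected here: compound 3 is estimated to give 70% in this assay, between 55% and 85%. The step of a number 2 percentage points higher from compound 2 to compound 3 (within the scatter) is therefore expected to stay within the scatter.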

Compound 3, a percentage reported as inhibition, at one concentration (the size of the read-out at that concentration, not a potency): 58%
Compound 3: middle estimate off by 12 percentage points, on the high side, and the stated range covers the measured number.
By their numbers in this assay, from the lowest: compounds 3, 2 and 1 (each within the scatter of the next, the first and the last beyond it).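

In this assay the change of 2-fluorophenyl to 4-bromophenyl gives a number 10 percentage points lower from compound 2 to compound 3 (within the scatter) and so still does not separate these two groups at this place. For the compounds shown here, the change of methyl to bromo on an aromatic carbon gives a number 18 percentage points lower from compound 1 to compound 3 (beyond the scatter) and is the first step in this set to clear the scatter, which shows that the substituent on this phenyl ring can matter, though only modestly and with compound 2 not separated from either neighbour. Nothing available explains this difference.

An unsubstituted benzyl, a 4-methoxybenzyl or a 4-chlorobenzyl at this place would show whether the gap follows the particular substituent. A single concentration also leaves open how far these numbers reflect differences in potency.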